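The compounds below may be only part of what the source reports. "The series", "measured", "known", "first", "only" and "open" are said of these compounds alone.

Measured so far:
- compound 1, `CCCCOC(=O)CCC(=O)N1CCN(CCCOc2cc3c(Nc4ccc(F)c(Cl)c4)ncnc3cc2OC)CC1`: 79.1%
- compound 2, `CCCCCCCCOC(=O)CCC(=O)N1CCN(CCCOc2cc3c(Nc4ccc(F)c(Cl)c4)ncnc3cc2OC)CC1`: 48.7%

Both compounds were tested in a functional assay on A549 cells (Homo sapiens) for cytotoxicity, read by MTT assay, with a stated time of 24 h, tested at 40 uM; a higher number here means a weaker effect of the compound at the concentration tested, a lower number a stronger effect. Compound 1 gives 79.1%, and compound 2 gives 48.7%, so compound 2 stands as the lower of the two numbers, that is the stronger effect of the two measured compounds. Among the measured compounds shown here, the one step measured so far, a number 30.4 percentage points lower from compound 1 to compound 2 (beyond the scatter), shows that lengthening the ester chain went together with a clearly stronger effect.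

Compound 3, `CCCCCCCCCCCOC(=O)CCC(=O)N1CCN(CCCOc2cc3c(Nc4ccc(F)c(Cl)c4)ncnc3cc2OC)CC1`, is not yet measured. It differs from compound 2 by propyl in place of hydrogen on a saturated chain carbon, eight bonds along the chain from an oxygen next to a carbonyl group. For the measured compounds named here, this is the same kind of change as the one measured step, only carried further out along the chain. Because a number 30.4 percentage points lower from compound 1 to compound 2 (beyond the scatter) was large, a further drop in this assay is expected for compound 3, though a step cut further out along the same chain need not be as large, and it could also stay within the scatter. The expected step is a number 13.7 percentage points lower from compound 2 to compound 3 (beyond the scatter). Compound 3 is therefore estimated at 35% in this assay, with a range from 15% to 60%.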

Compound 3, a percentage reported as activity, at one concentration (the size of the read-out at that concentration, not a potency): 12%
Estimate against measurement, compound 3: 23 percentage points above, and the stated range ends above it.
By their numbers in this assay, from the lowest: compound 3; then compound 2; then compound 1.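

Carrying the change further out along the ester chain did not exhaust the effect: propyl in place of hydrogen, eight bonds along the chain from an oxygen next to a carbonyl group, still gives a number 36.7 percentage points lower from compound 2 to compound 3 (beyond the scatter) in this assay. This step is printed as large, just as the earlier step nearer the ester was, so this far position is not a spot where added carbon stops mattering, and the whole change, heptyl in place of hydrogen at the inner position, amounts to a number 67.1 percentage points lower from compound 1 to compound 3 (beyond the scatter). Across these three compounds the number falls each time the chain grows, none goes against that pattern, and compound 3 now shows the strongest effect of the series, although no measurement shown here explains why the effect follows chain length.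

Three chain lengths cannot show where this trend ends, so a longer chain might lower the number further, leave it level or reverse it. On these data alone, it also remains open whether an amine or a carboxylic acid in place of the propyl would keep the drop, or whether carbon chain alone goes with it.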